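This account rests on a few compounds, and the source may have more. Where it says the series, first, only, none or still open, it means among the compounds named here.

Measured in an ADME assay on HEK293 cells (Homo sapiens) for cytotoxicity; a higher number here means a weaker inhibitor, a lower number a stronger inhibitor:
- Compound 1 `COC(=O)c1c(C)cc(OC(=O)c2c(C)cc(O)c(/C=N/NC(=O)CNc3ccc(C)cc3)c2O)c(C)c1O`: > 100000 nM, a limit
- Compound 2 `COC(=O)c1c(C)cc(OC(=O)c2c(C)cc(O)c(/C=N/NC(=O)COc3cccc(C)c3)c2O)c(C)c1O`: > 100000 nM, a limit

Among the measured compounds shown here, compound 2 has no number, only a limit, and the same is true of the only other measured compound. For the measured compounds named here, the series so far shows (the limit of > 100000 nM in this assay, at which 2 of the 2 values shown sit).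

Compound 3 `COC(=O)c1c(C)cc(OC(=O)c2c(C)cc(O)c(/C=N/NC(=O)COc3ccc(C)cc3)c2O)c(C)c1O` keeps the core of compound 2 and has 4-methylphenyl in place of 3-methylphenyl on an oxygen on a saturated carbon.

Going by the values given here, only one measured step bears on this change: a step that the two limits leave unreadable from compound 1 to compound 2. It gives no size to carry over, and it concerns a different change. The expectation therefore rests on compound 2, whose > 100000 nM is a limit. No step beyond the scatter is expected in this assay, and a further limit is the likeliest report. The expected step, taken on the estimate, is a number no higher from compound 2 to compound 3 (the limit leaves the size open). Compound 3 is estimated at 100000 nM, with an expected range of 50000 nM to 200000 nM.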

Compound 3, half-maximal inhibitory concentration: > 100000 nM
Compound 3 gave a limit, no number; the forecaster's own chance of this, stated with the estimate: 85%; the middle value sits exactly at the limit.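

Compound 3 adds no readable step to compound 1 and compound 2 in this assay, since all three results are limits and not numbers: the limit of > 100000 nM in this assay, at which 3 of the 3 values shown sit.

Still open, going by these compounds, is whether 4-methylphenyl in place of 3-methylphenyl, or 4-methylphenoxy in place of (4-methylphenyl)amino, changes the half-maximal inhibitory concentration in this assay at all, and by how much.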